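The compounds below may be only part of what the source reports. "The series", "measured", "known", "first", "only" and "open" are said of these compounds alone.

Of the compounds shown here, three sharing one core have been tested in a functional assay on B16-F10 cells (Mus musculus) for inhibition, read by MTT assay, with a stated time of 72 h; on this read-out higher numbers stand for weaker inhibition and lower numbers for stronger inhibition. Compound 1 `CC(C)c1ccc(-c2nc(SCc3cn(CC(=O)NC(=O)Nc4ccccn4)nn3)nc(Nc3ccc(Cl)cc3)c2C#N)cc1` carries a 4-chlorophenyl on the ring nitrogen and gives 860 nM. Compound 2 `CC(C)c1ccc(-c2nc(SCc3cn(CC(=O)NC(=O)Nc4ccccn4)nn3)nc(Nc3ccccc3)c2C#N)cc1` carries a plain phenyl there and gives 14300 nM. Compound 3 `COc1ccccc1Nc1nc(SCc2cn(CC(=O)NC(=O)Nc3ccccn3)nn2)nc(-c2ccc(C(C)C)cc2)c1C#N` carries a 2-methoxyphenyl and gives 34600 nM, the highest of the three numbers, so it is the weakest inhibitor in this set, with compound 2 nearest to it and compound 1 furthest away.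

Compound 4 `CC(C)c1ccc(Nc2nc(SCc3cn(CC(=O)NC(=O)Nc4ccccn4)nn3)nc(-c3ccc(C(C)C)cc3)c2C#N)cc1` is the next member. Relative to compound 3 the change is 4-isopropylphenyl in place of 2-methoxyphenyl on a nitrogen on an aromatic ring. Among the measured compounds shown here, two measured steps bear on this. Going from compound 1 to compound 3 (a 40-fold higher number from compound 1 to compound 3 (1.60 log units; beyond the scatter)) shows that swapping a 4-chlorophenyl for a 2-methoxyphenyl on this nitrogen costs a great deal of inhibition; going from compound 2 to compound 3 (a 2.4-fold higher number from compound 2 to compound 3 (0.38 log units; beyond the scatter)) shows that the methoxy alone accounts for only a small part of that. Returning to a phenyl carrying a single substituent of the same kind as in compound 1, though with isopropyl rather than chloro, is therefore expected to lower the number substantially, by about a 14-fold lower number from compound 3 to compound 4 (1.14 log units; beyond the scatter). For compound 4 the estimate in this assay is 2500 nM, with a likely range from 600 nM to 10000 nM.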

Compound 4, half-maximal inhibitory concentration: 4380 nM
The estimate for compound 4 lay 1.8-fold (0.24 log units) below the measured number; the range from low to high includes it.
By their numbers in this assay, from the lowest: compound 1; then compound 4; then compound 2; then compound 3.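

In this assay, the plain phenyl of compound 2 is not the only ring to be improved by a single added group. Isopropyl in place of hydrogen also lowers the number, with a 3.3-fold lower number from compound 2 to compound 4 (0.51 log units; beyond the scatter). The added group's identity still matters: isopropyl in place of chloro gives a 5.1-fold higher number from compound 1 to compound 4 (0.71 log units; beyond the scatter), so compound 1 keeps the lowest number of the four, and 4-isopropylphenyl recovers only part of what 4-chlorophenyl gives. On this nitrogen, 4-isopropylphenyl in place of 2-methoxyphenyl gives a 7.9-fold lower number from compound 3 to compound 4 (0.90 log units; beyond the scatter), which places the two substituted rings on opposite sides of the plain phenyl, and nothing shown here explains these differences.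

The four compounds do not separate the identity of a group from where it sits on the ring, since the methoxy appears only in 2-methoxyphenyl and the chloro and isopropyl only in 4-substituted rings; a 4-methoxyphenyl would bear directly on that. On these data alone, it also remains open whether other groups in the same place, such as 4-bromophenyl or 4-aminophenyl, would fall nearer compound 1 or compound 4.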